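A few compounds are considered here, and "the series" means these few. Any claim that something is new, unique, unknown or untested is made for them only; others in the source may bear on it.

Measured compounds:
compound 1 `Cc1nc(-c2ccc(C(F)(F)F)cc2)sc1CNc1ccc(CCC(=O)O)cc1` gives 108% in a functional assay on CHO cells for agonist activity at Free fatty acid receptor 1 (Homo sapiens), read by a luciferase reporter; on this read-out lower numbers stand for smaller maximal responses and higher numbers for larger maximal responses
compound 2 `O=C(O)CCCc1ccc(NCc2cccc(Oc3ccccc3)c2)cc1` gives 59% in this assay

Going by the values given here, of the two compounds measured, compound 2 stands lowest on the largest response reached, and the gap to compound 1, the only neighbour, lies beyond the usual scatter. Compound 3 `NC(=O)CCc1ccc(NCc2cccc(Oc3ccccc3)c2)cc1` is not yet measured; it differs from compound 2 in one place: carbamoyl in place of carboxymethyl on a saturated chain carbon, two bonds along the chain from an aromatic carbon. Among the compounds with values here, no step between measured compounds carries this kind of change, so the expectation for compound 3 rests only on the shared core with compound 2 and on the acid group being replaced by carbamoyl. The estimated step from compound 2 to compound 3 in this assay is a loss beyond the scatter, a number 29 percentage points lower from compound 2 to compound 3 (beyond the scatter). For compound 3 the estimated largest response reached is 30%, expected to lie between 5% and 65%.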

Compound 3, largest response reached (reported as percent of maximum), in percent of the reference or control that the assay uses: 68%
Estimate against measurement, compound 3: 38 percentage points below; measured number outside the range, above it.
By their numbers in this assay, from the lowest: compounds 2 and 3 (each within the scatter of the next); then compound 1.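

The earlier compounds shown here all carried a carboxylic acid, so they could not show what happens at this position without one. In this assay, exchanging carboxymethyl for carbamoyl on this saturated chain carbon gives a number 9 percentage points higher from compound 2 to compound 3 (within the scatter), so the two compounds cannot be told apart on largest response, and a substantial response persists with the carboxylic acid gone. Read one bond further out, the change is 3-carboxypropyl to 2-carbamoylethyl, which means that the end group and the chain differ together in this single step. Nothing available explains why the response persists.

Which of those two differences matters, if either, stays open, and a 3-carbamoylpropyl group would separate them. From the compounds shown here alone, whether a nitrile, a hydroxyl or an amine in place of carbamoyl would hold the response also remains unknown.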